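This account rests on a few compounds, and the source may have more. Where it says the series, first, only, none or still open, it means among the compounds named here.

Measured in a functional assay on DU-145 cells (Homo sapiens) for antiproliferative activity, read by MTT assay, with a stated time of 48 h; a higher number here means a weaker inhibitor, a lower number a stronger inhibitor:
Compound 1 `C/C(=C\CC/C(C)=C/CC[C@@H]1[C@@]2(C)CCC(=O)C(C)(C)[C@H]2CC[C@@]1(C)O)CC/C=C(\C)C(=O)OCc1cn(-c2ccc(Br)cc2)nn1`: > 150000 nM, a limit
Compound 2 `C/C(=C\CC/C(C)=C/CC[C@@H]1[C@@]2(C)CCC(=O)C(C)(C)[C@H]2CC[C@@]1(C)O)CC/C=C(\C)C(=O)OCc1cn(-c2ccccc2)nn1`: 95500 nM
Compound 3 `C/C(=C\CC/C(C)=C/CC[C@@H]1[C@@]2(C)CCC(=O)C(C)(C)[C@H]2CC[C@@]1(C)O)CC/C=C(\C)C(=O)OCc1cn(-c2cccc(F)c2)nn1`: > 150000 nM, a limit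

Compound 3 has no number in this assay, only the limit > 150000 nM. Compound 3 thus sits at the limit of > 150000 nM in this assay, at which 2 of the 3 values shown sit.

Compound 4 `C/C(=C\CC/C(C)=C/CC[C@@H]1[C@@]2(C)CCC(=O)C(C)(C)[C@H]2CC[C@@]1(C)O)CC/C=C(\C)C(=O)OCc1cn(-c2ccccc2F)nn1` has the same atoms joined differently: 2-fluorophenyl in place of 3-fluorophenyl on an aromatic nitrogen. It carries 2-fluorophenyl in place of 3-fluorophenyl on an aromatic nitrogen. Among the measured compounds shown here, no measured step covers this exact change. The closest evidence is an at least 1.5-fold higher number from compound 2 to compound 3 (0.19 log units; that floor lies within the scatter), together with an at least 1.5-fold lower number from compound 1 to compound 2 (0.19 log units; that floor lies within the scatter). Both are floors that lie within the scatter, and a step that the two limits leave unreadable from compound 1 to compound 3 cannot be read at all. The data therefore give no reason to expect a step beyond the scatter in this assay, and they fix no direction. The expected change is an at least 1.1-fold lower number from compound 3 to compound 4 (0.06 log units; that floor lies within the scatter), an estimate that stays within the scatter. For the measured compounds named here, the estimate rests on the one number, the value of compound 2 at 95500 nM. It rests as well on the limit that compound 1 and compound 3 share. Compound 4 is expected at 130000 nM, with an estimated range of 75000 nM to 220000 nM.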

Compound 4, half-maximal inhibitory concentration: > 150000 nM
Compound 4 ended at the assay's limit; the forecaster's own chance of this, stated with the estimate: 50%; middle value at least 1.1-fold (0.06 log units) from the limit.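

In this assay compound 4 gives > 150000 nM, which is a limit and not a number, so the 2-fluorophenyl group, like the 3-fluorophenyl group before it, yields no readable value, and the steps among the compounds at this limit cannot be read. Set against the unsubstituted phenyl of compound 2, the fluoro group gives an at least 1.5-fold higher number from compound 2 to compound 4 (0.19 log units; that floor lies within the scatter), a floor and no more. Compound 2 remains the only one of the four with a number, and the limit now takes in both fluorophenyl compounds and the 4-bromophenyl compound: the limit of > 150000 nM in this assay, at which 3 of the 4 values shown sit.

As far as these compounds go, how far compound 1, compound 3 and compound 4 lie past the limit stays unknown, so the fluoro positions cannot be ranked. From the compounds shown here alone, whether an amine or a methoxy group on the phenyl ring would give a number in this assay also remains open.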